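Changing the aryl group on a thioether-linked nucleoside

The compounds below may be only part of what the source reports. "The series", "measured", "known", "first", "only" and "open" are said of these compounds alone.

Compound 2 `OC[C@H]1O[C@@H](n2cnc3c(CSc4ccccc4Cl)ncnc32)[C@H](O)[C@@H]1O`: 1780 nM
Compound 1 `OC[C@H]1O[C@@H](n2cnc3c(NCc4ccco4)ncnc32)[C@H](O)[C@@H]1O`: 36300 nM

Going by the values given here, in an assay on isolated protein for binding affinity to Equilibrative nucleoside transporter 1 (Homo sapiens) (on this read-out higher numbers stand for weaker inhibition and lower numbers for stronger inhibition), compound 2 gives 1780 nM, the lowest of the two numbers, while compound 1 gives 36300 nM; the only measured step is a 20-fold lower number from compound 1 to compound 2 (1.31 log units; beyond the scatter). Compound 3 `N#Cc1ccc(SCc2ncnc3c2ncn3[C@@H]2O[C@H](CO)[C@@H](O)[C@H]2O)cc1` differs from compound 2 by 4-cyanophenyl in place of 2-chlorophenyl on a sulfur. Among the compounds with values here, this change keeps the sulfur and alters only the aryl group attached to it; no measured pair varies that group, so the one measured step does not bear on it. Compound 3 is therefore expected to give a step of a 1.1-fold higher number from compound 2 to compound 3 (0.05 log units; within the scatter), most likely within the scatter. The estimate for compound 3 is 2000 nM, ranging from 600 nM to 7000 nM.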

Compound 3, half-maximal inhibitory concentration: 81.3 nM
Estimate against measurement, compound 3: 25-fold (1.39 log units) above; measured number below the stated range.
By their numbers in this assay, from the lowest: compound 3; then compound 2; then compound 1.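

Exchanging 2-chlorophenyl for 4-cyanophenyl on the sulfur gives a 22-fold lower number from compound 2 to compound 3 (1.34 log units; beyond the scatter) in this assay, so the aryl group alone, with the sulfur and its saturated chain carbon kept, moves the number beyond the scatter. Compound 1 and compound 2 differed in the whole side group and could not show this. Nothing available explains this step. The change replaces both the substituent and its printed ring number, so the compounds leave open which of the two matters. From the compounds shown here alone, whether a carboxylic acid or an amine could stand in place of the nitrile also remains open.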